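From (1-Methylcyclopropyl)methoxy to Neopentyloxy

The compounds below may be only part of what the source reports. "The series", "measured", "known", "first", "only" and "open" are said of these compounds alone.

Three compounds have been measured in an assay on cells for binding affinity to Neuropeptide Y receptor type 1 (Homo sapiens); on this read-out higher numbers stand for weaker inhibition and lower numbers for stronger inhibition:

compound 1 `CCOc1cc(CCc2nc(C)c(CC)s2)nc(NCc2cc(Cl)cc(NC(=O)OC(C)C)c2)c1`: 33 nM
compound 2 `CCCCOc1cc(CCc2nc(C)c(CC)s2)nc(NCc2cc(Cl)cc(NC(=O)OC(C)C)c2)c1`: 16 nM
compound 3 `CCc1sc(CCc2cc(OCC3(C)CC3)cc(NCc3cc(Cl)cc(NC(=O)OC(C)C)c3)n2)nc1C`: 17 nM

Compound 3 sits within the usual scatter of both neighbours: the changes a 1.9-fold lower number from compound 1 to compound 3 (0.29 log units; within the scatter) and a 1.1-fold higher number from compound 2 to compound 3 (0.03 log units; within the scatter) are small, while only a 2.1-fold lower number from compound 1 to compound 2 (0.31 log units; beyond the scatter) reaches beyond the scatter. Compound 4 `CCc1sc(CCc2cc(OCC(C)(C)C)cc(NCc3cc(Cl)cc(NC(=O)OC(C)C)c3)n2)nc1C` differs from compound 3 by tert-butyl in place of 1-methylcyclopropyl on a saturated chain carbon bound to an oxygen on an aromatic ring. Both earlier exchanges of one alkyl group for another at this place (a 1.9-fold lower number from compound 1 to compound 3 (0.29 log units; within the scatter), a 1.1-fold higher number from compound 2 to compound 3 (0.03 log units; within the scatter)) stayed within the scatter, so compound 4 is expected to show no step beyond the scatter in this assay, an estimated 1.1-fold higher number from compound 3 to compound 4 (0.02 log units; within the scatter). Compound 4 is thus estimated at 18 nM, between 8 nM and 40 nM.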

Compound 4, half-maximal inhibitory concentration: 55 nM
Compound 4: middle estimate off by 3.1-fold (0.49 log units), on the low side; measured number outside the range, above it.
By their numbers in this assay, from the lowest: compounds 2, 3, 1 and 4 (each within the scatter of the next, the first and the last beyond it).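

At the saturated chain carbon bound to an oxygen on an aromatic ring, the alkyl group's shape matters in this assay: tert-butyl in place of 1-methylcyclopropyl, both of 4 heavy atoms, gives a 3.2-fold higher number from compound 3 to compound 4 (0.51 log units; beyond the scatter) and so separates two groups that differ chiefly in the ring. Tert-butyl in place of propyl gives a 3.4-fold higher number from compound 2 to compound 4 (0.54 log units; beyond the scatter) as well, whereas tert-butyl in place of methyl gives a 1.7-fold higher number from compound 1 to compound 4 (0.22 log units; within the scatter) and stays close to the shorter chain. No evidence at hand accounts for these steps.

On these data alone, whether cyclobutyl or a longer chain at this place would stay with compound 2 and compound 3 remains open, as does the effect of an amine at the chain end.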